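From a fluorophenyl amide to a methoxyphenyl amide

A few compounds are considered here, and "the series" means these few. Any claim that something is new, unique, unknown or untested is made for them only; others in the source may bear on it.

Measured compounds:
- compound 1 `COc1ccccc1C(=O)NC(CC(=O)O)c1ccccc1` gives > 100000 nM (a limit)
- compound 2 `CC(C)(C)c1ccc(C(CC(=O)O)NC(=O)c2ccc(F)cc2)cc1` gives 87600 nM

Among the measured compounds shown here, in a functional assay on MDA-MB-231 cells (Homo sapiens) for antiproliferative activity, read by MTT assay, with a stated time of 24 h (a higher number here means a weaker inhibitor, a lower number a stronger inhibitor), compound 2 gives 87600 nM and is the only compound here with an actual number. Compound 1 gives > 100000 nM as a limit of the assay and not a number. These two compounds differ in more than one place, so no single structural step can be read from them.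

Compound 3 `COc1ccccc1C(=O)NC(CC(=O)O)c1ccc(C(C)(C)C)cc1` has not yet been measured. It differs from compound 2 by one change, (2-methoxyphenyl in place of 4-fluorophenyl on a carbonyl carbon), with 2-methoxyphenyl in place of 4-fluorophenyl on a carbonyl carbon.

For the measured compounds named here, with no measured step to draw on, no shift beyond the usual scatter is expected in this assay in either direction. The expected step of a 1.0-fold lower number from compound 2 to compound 3 (0.01 log units; within the scatter) is correspondingly small. Compound 1 carries the same 2-methoxyphenyl and its reading is a limit (the limit of > 100000 nM in this assay, at which 1 of the 2 values shown sits), so a limit is also expected to be possible for compound 3. Compound 3 is estimated at 85000 nM, with an expected range from 40000 nM to 170000 nM.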

Compound 3, half-maximal inhibitory concentration: > 100000 nM
Compound 3 ended at the assay's limit; the forecaster's own chance of this, stated with the estimate: 35%; middle value at least 1.1-fold (0.07 log units) away from the limit.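

In this assay, compound 3 gives > 100000 nM, which is a limit of the assay and not a number. Placing 2-methoxyphenyl in place of 4-fluorophenyl on a carbonyl carbon whose other neighbour is an amide-type nitrogen gives an at least 1.1-fold higher number from compound 2 to compound 3 (0.05 log units; that floor lies within the scatter), so this change brings no measurable gain in antiproliferative activity at this position, and it cannot be called a loss beyond the scatter either. The step that adds tert-butyl in place of hydrogen on an aromatic carbon cannot be read, as both of its ends are limits: the limit of > 100000 nM in this assay, at which 2 of the 3 values shown sit.

Where compound 3 truly stands relative to compound 2 remains open, and so does whether tert-butyl has any effect when 2-methoxyphenyl sits on the carbonyl carbon. Also open, from the compounds shown here alone, is whether an amine or a longer chain in place of 2-methoxyphenyl on that carbonyl carbon would give a reading well inside the range of this assay.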